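The source may report more compounds than this note shows. Statements on the series, on what has been measured and on what is new or still open speak of the compounds shown alone.

Measured so far:
compound 1 `CCOC(=O)C[C@H]1[C@@H](O[Si](C)(C)C(C)(C)C)[C@H](n2cnc3c(NC(=O)Nc4ccccc4)ncnc32)O[C@@H]1COC(=O)NC`: 8.76 nM
compound 2 `CNC(=O)NC[C@H]1O[C@@H](n2cnc3c(NC(=O)Nc4ccccc4)ncnc32)[C@H](O[Si](C)(C)C(C)(C)C)[C@@H]1CC(=O)N(C)OC`: 30.6 nM

Of the compounds shown here, two sharing the same core have been tested in a functional assay on HCC 2998 cells (Homo sapiens) for antiproliferative activity; on this read-out higher numbers stand for weaker inhibition of growth and lower numbers for stronger inhibition of growth. In this assay compound 1 gives 8.76 nM, and compound 2 gives 30.6 nM. Compound 2 thus stands at the higher of the two numbers, and the gap to compound 1 lies beyond the usual scatter of repeated measurements, so compound 2 is the weaker grower-inhibitor of the pair.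

The next compound, compound 3 `CCOC(=O)C[C@H]1[C@@H](O[Si](C)(C)C(C)(C)C)[C@H](n2cnc3c(NC(=O)Nc4ccccc4)ncnc32)O[C@@H]1CNC(=O)NC`, has not yet been measured in this assay. It differs from compound 2 in one place: ethoxy in place of methoxy(methyl)amino on a carbonyl carbon. Within the data shown here, no pair of measured compounds differing only in this way is available, so the size of the step cannot be read off directly. A modest step toward a lower number is expected, and the step from compound 2 to compound 3 is estimated at a 2.0-fold lower number from compound 2 to compound 3 (0.31 log units; beyond the scatter). On this basis compound 3 is expected to give about 15 nM in this assay, with a likely range from 5 nM to 45 nM.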

Compound 3, concentration for 50% growth inhibition: > 100 nM
Compound 3 was reported as a limit; the forecaster's own chance of this, stated with the estimate: 2%; middle value at least 6.6-fold (0.82 log units) away from the limit.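

In this assay compound 3 gives > 100 nM, which is a limit of the assay and not a number. With the (methylcarbamoyl)amino group held in place, ethoxy in place of methoxy(methyl)amino on a carbonyl carbon brings an at least 3.2-fold higher number from compound 2 to compound 3 (0.51 log units; beyond the scatter), so the group on this carbonyl carbon clearly matters, and here the ester is the weaker inhibitor of growth. With the ethoxycarbonyl group held in place, (methylcarbamoyl)amino in place of (methylcarbamoyl)oxy on a saturated chain carbon bound to a saturated ring carbon brings an at least 11-fold higher number from compound 1 to compound 3 (1.05 log units; beyond the scatter), so this second place matters as well, and this large step shows that swapping the linking oxygen for nitrogen in that side chain is not a neutral change.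

The true size of both steps stays open, as each could be larger than printed: the limit of > 100 nM in this assay, at which 1 of the 3 values shown sits.

Also open, from the compounds shown here alone, are the reasons for either step, and how other groups on the same carbonyl carbon, such as a carboxylic acid, a simple dimethylamino group or a longer alkoxy chain, would behave alongside the (methylcarbamoyl)amino side chain.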